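The compounds below may be only part of what the source reports. "The series", "measured", "known", "first", "only" and "open" are said of these compounds alone.

Values in a physicochemical assay for solubility; a lower number here means a less soluble compound, a higher number a more soluble compound:

- compound 1 `CNC(=O)c1ccc(=O)n(Cc2cc(Br)ccc2F)c1`: >= 143 ug/mL
- compound 2 `CNC(=O)c1cc(C(=O)NCCCC2CNCCO2)cn(Cc2ccccc2)c1=O`: >= 194 ug/mL
- compound 3 `CNC(=O)c1cc(C(=O)NC2CC2)cn(CC2CCCCC2)c1=O`: >= 148 ug/mL

Compound 2 stands at >= 194 ug/mL, which is a limit of the assay and not a number. Compound 1 gives >= 143 ug/mL, also a limit. Compound 3 gives >= 148 ug/mL, also a limit. The three results therefore cannot be ranked against one another.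

The next compound to be read is compound 4 `CNC(=O)c1cc(C(=O)NC(C)C)cn(Cc2ccccc2)c1=O`. Its difference from compound 2 is isopropyl in place of 3-(morpholin-2-yl)propyl on an amide-type nitrogen. Among the compounds with values here, no two measured compounds differ in one place only, so the series offers no measured step for this change.

The expectation leans on compound 3, which also lacks the 3-(morpholin-2-yl)propyl and stands at >= 148 ug/mL, a limit. Compound 1 lacks that group as well and stands at >= 143 ug/mL, a limit. On that basis, no step beyond the scatter is expected in this assay, and any movement is expected to be slightly downward: an at least 1.3-fold lower number from compound 2 to compound 4 (0.14 log units; that floor lies within the scatter). A further limit rather than a number is a likely outcome. For compound 4 the estimate is 140 ug/mL, with an expected range of 70 ug/mL to 190 ug/mL.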

Compound 4, solubility: >= 136 ug/mL
Compound 4 was reported as a limit; the forecaster's own chance of this, stated with the estimate: 65%; the middle value is on the limit's open side.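

In this assay compound 4 gives >= 136 ug/mL, a limit of the assay and not a number. Compound 2 gives >= 194 ug/mL, also a limit, and no step can be read between compound 2 and compound 4. The compounds shown leave open what isopropyl in place of 3-(morpholin-2-yl)propyl on an amide-type nitrogen does to the read-out of this assay.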